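Shifting the Chlorine on the Aryl Group of Compound 1

The source may hold more compounds than are shown below. What is called first, only, known or untested is meant among the compounds shown, and "the series" means these compounds.

compound 1 `Fc1ccc2c(c1)CCC(c1nnc(-c3cccc(Cl)c3)o1)O2`: 23100 nM
compound 2 `O=[N+]([O-])c1ccc(-c2nnc(C3CCc4cc(F)ccc4O3)o2)cc1`: 28700 nM
compound 3 `Fc1ccc2c(c1)CCC(c1nnc(-c3cnccn3)o1)O2`: 73400 nM

In a functional assay (a higher number here means a weaker inhibitor, a lower number a stronger inhibitor), compound 1 gives 23100 nM, the lowest of the three numbers, but compound 2 with 28700 nM lies within the scatter of it, so the two cannot be ranked. Within the data shown here, compound 3 with 73400 nM lies beyond the scatter, and the one measured step on the same aromatic carbon is a 3.2-fold higher number from compound 1 to compound 3 (0.50 log units; beyond the scatter). The change to compound 4 `Fc1ccc2c(c1)CCC(c1nnc(-c3ccc(Cl)cc3)o1)O2` is 4-chlorophenyl in place of 3-chlorophenyl on an aromatic carbon. Among the measured compounds shown here, no measured step exchanges one chlorophenyl for another: the step to compound 3 replaces the aryl group with a different ring altogether, and compound 2, which carries a 4-nitrophenyl on that carbon, is within the scatter of compound 1. Taken together, these give no ground to expect a step beyond the scatter. Compound 4 is therefore estimated at 25000 nM (range 8000 nM to 80000 nM), an expected step of a 1.1-fold higher number from compound 1 to compound 4 (0.03 log units; within the scatter) that should stay within the usual scatter.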

Compound 4, half-maximal inhibitory concentration: 17200 nM
Compound 4: middle estimate off by 1.5-fold (0.16 log units), on the high side; the measured number falls inside the stated range.
By their numbers in this assay, from the lowest: compounds 4, 1 and 2 (each within the scatter of the next); then compound 3.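

Among these compounds, exchanging 3-chlorophenyl for 4-chlorophenyl is the first step at this position that keeps the same atoms and only rearranges them, and in this assay it gives a 1.3-fold lower number from compound 1 to compound 4 (0.13 log units; within the scatter), so the two chlorophenyl groups cannot be ranked. Chloro in place of nitro on the phenyl ring gives a 1.7-fold lower number from compound 2 to compound 4 (0.22 log units; within the scatter), so compound 2 and compound 4 cannot be ranked either, whereas a 4.3-fold lower number from compound 3 to compound 4 (0.63 log units; beyond the scatter) separates compound 3 from compound 4 just as compound 3 was already separated from compound 1. Among the four compounds, the three that carry a substituted phenyl therefore stay together and only the pyrazin-2-yl compound stands apart, though nothing available explains this.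

The compounds shown leave open whether an amine or a carboxylic acid on that phenyl ring would move the number beyond the scatter. They also leave open how a pyridine ring would compare with the pyrazin-2-yl of compound 3.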